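Adding a Piperidinyl Ring to a Hydroxamic Acid Inhibitor

A few compounds are considered here, and "the series" means these few. Any claim that something is new, unique, unknown or untested is made for them only; others in the source may bear on it.

Compound 1 (`O=C(CCCCCCCC(=O)c1ccccc1)NO`) is the reference here. In an assay on isolated protein for inhibition of histone deacetylase 8 (Homo sapiens) (on this read-out higher numbers stand for weaker inhibition and lower numbers for stronger inhibition), compound 1 gives 65 nM. Compound 3 (`COc1ccccc1C(=O)CCCCCCCC(=O)NO`) gives 95 nM in this assay, and the step of a 1.5-fold higher number from compound 1 to compound 3 (0.16 log units; within the scatter) lies within the scatter. Compound 2 (`O=C(CCCCCCCCC(=O)c1ccccc1)NO`) gives 135 nM, and the step of a 2.1-fold higher number from compound 1 to compound 2 (0.32 log units; beyond the scatter) is a modest weakening. Compound 4 (`O=C(CCCCCCCC(=O)c1ccc(N2CCCCC2)cc1)NO`) differs from compound 1 by piperidin-1-yl in place of hydrogen on an aromatic carbon. For the measured compounds named here, the only measured step that alters the aromatic ring is a 1.5-fold higher number from compound 1 to compound 3 (0.16 log units; within the scatter), which stayed within the scatter; the chain change behind a 2.1-fold higher number from compound 1 to compound 2 (0.32 log units; beyond the scatter) does not bear on this substitution. For compound 4 the expected step is therefore a 1.2-fold higher number from compound 1 to compound 4 (0.09 log units; within the scatter), nothing beyond the scatter. The estimate for compound 4 is 80 nM, ranging from 30 nM to 220 nM.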

Compound 4, half-maximal inhibitory concentration: 9.5 nM
Compound 4: middle estimate off by 8.4-fold (0.93 log units), on the high side; measured number outside the range, below it.
By their numbers in this assay, from the lowest: compound 4; then compounds 1, 3 and 2 (each within the scatter of the next, the first and the last beyond it).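

In this assay, piperidin-1-yl in place of hydrogen on an aromatic carbon, para to a large group, gives a 6.8-fold lower number from compound 1 to compound 4 (0.84 log units; beyond the scatter). This is the only step shown that goes to stronger inhibition, so this aromatic carbon can carry a large ring and gain from it. Nothing available explains the gain.

Going by these compounds, it remains open whether the gain needs the whole ring or only its nitrogen, which a dimethylamino group or a morpholin-4-yl ring on the same carbon could help to separate. Whether the gain also holds on the longer chain of compound 2 is open too.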